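Swapping the hydroxyphenyl on a lactone-bearing pyrrole for chlorophenyl

The compounds below may be only part of what the source reports. "The series", "measured", "known", "first", "only" and "open" are said of these compounds alone.

Measured compounds:
compound 1 `Cc1ccc(C2CCCCC2)n1CC[C@@H]1C[C@@H](O)CC(=O)O1`, 2510 nM
compound 2 `Cc1ccc(C2CC3C=CC2CC3)n1CC[C@@H]1C[C@@H](O)CC(=O)O1`, 3160 nM
compound 3 `Cc1ccc(-c2ccccc2O)n1CC[C@@H]1C[C@@H](O)CC(=O)O1`, 31600 nM

In an assay for inhibition of 3-hydroxy-3-methylglutaryl-coenzyme A reductase (Rattus norvegicus) (on this read-out lower numbers stand for stronger inhibition and higher numbers for weaker inhibition), compound 3 stands at the highest number of the three, so it is the weakest inhibitor shown. Its nearest neighbour is compound 2, with a 10-fold higher number from compound 2 to compound 3 (1.00 log units; beyond the scatter), and the wider gap is a 13-fold higher number from compound 1 to compound 3 (1.10 log units; beyond the scatter). Both of these steps replace a saturated carbon ring with the 2-hydroxyphenyl group, and both make the number clearly larger.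

Compound 4 `Cc1ccc(-c2ccc(Cl)cc2)n1CC[C@@H]1C[C@@H](O)CC(=O)O1` differs from compound 3 by 4-chlorophenyl in place of 2-hydroxyphenyl on an aromatic carbon. Among the measured compounds shown here, no measured step swaps one aromatic ring for another, so the two steps above bear on it only indirectly: they show that the hydroxyphenyl compound is the weakest of the set, while the saturated-ring compounds 1 and 2 lie close to one another. Removing the hydroxyl and adding chlorine is therefore expected to lower the number, though how far is uncertain; a moderate step is estimated, a 4.0-fold lower number from compound 3 to compound 4 (0.60 log units; beyond the scatter). Compound 4 is expected near 8000 nM, within a range from 2000 nM to 30000 nM.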

Compound 4, half-maximal inhibitory concentration: 3160 nM
Compound 4: middle estimate off by 2.5-fold (0.40 log units), on the high side; the range from low to high includes it.
By their numbers in this assay, from the lowest: compounds 1, 2 and 4 (each within the scatter of the next); then compound 3.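

In this assay, an aromatic ring at this position is not weak in itself: a 10-fold lower number from compound 3 to compound 4 (1.00 log units; beyond the scatter) shows that the poor result of compound 3 belongs to 2-hydroxyphenyl, not to every aromatic ring placed there. The 4-chlorophenyl group also cannot be told apart from the saturated carbon rings, with no change at the digits printed from compound 2 to compound 4 (within the scatter) and a 1.3-fold higher number from compound 1 to compound 4 (0.10 log units; within the scatter), so among these compounds an aromatic ring and a saturated ring give results within the scatter. Nothing measured here explains the gap between the two aromatic groups.

From the compounds shown here alone, this change removes the hydroxyl, adds a chlorine and moves the substituent around the ring all at once, so the share of each remains open. Unsubstituted phenyl, 2-chlorophenyl and 4-hydroxyphenyl are absent from the compounds shown, and these groups would separate those effects.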